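Same chain amine change, checked on a second aryl partner

The source may report more compounds than this note shows. Statements on the series, on what has been measured and on what is new or still open speak of the compounds shown alone.

Compound 1 `COc1cc2c(Oc3ccc(NC(=O)c4nn(-c5ccccc5C)c(=O)cc4C)cc3F)ccnc2cc1OCCCN1CCC(C)CC1` and compound 2 `COc1cc2c(Oc3ccc(NC(=O)c4nn(-c5ccccc5C)c(=O)cc4C)cc3F)ccnc2cc1OCCCN1CCN(C)CC1` differ only by 4-methylpiperazin-1-yl in place of 4-methylpiperidin-1-yl on a saturated chain carbon, three bonds along the chain from an oxygen on an aromatic ring. In a functional assay on MKN-45 cells (Homo sapiens) for inhibition, read by MTT assay, with a stated time of 72 h (on this read-out lower numbers stand for stronger inhibition and higher numbers for weaker inhibition), compound 1 gives 1290 nM and compound 2 gives 1630 nM, a step of a 1.3-fold higher number from compound 1 to compound 2 (0.10 log units; within the scatter). Compound 3 `COc1cc2c(Oc3ccc(NC(=O)c4nn(-c5cccc(F)c5)c(=O)cc4C)cc3F)ccnc2cc1OCCCN1CCC(C)CC1` keeps the chain amine of compound 1 but carries 3-fluorophenyl in place of 2-methylphenyl on an aromatic nitrogen; in this assay compound 3 gives 140 nM, a step of a 9.2-fold lower number from compound 1 to compound 3 (0.96 log units; beyond the scatter), and it stands lowest of the three measured values. Compound 4 `COc1cc2c(Oc3ccc(NC(=O)c4nn(-c5cccc(F)c5)c(=O)cc4C)cc3F)ccnc2cc1OCCCN1CCN(C)CC1` is not yet measured and differs from compound 3 by 4-methylpiperazin-1-yl in place of 4-methylpiperidin-1-yl on a saturated chain carbon, three bonds along the chain from an oxygen on an aromatic ring, the same change that separates compound 1 from compound 2, made at the same place. For compound 4 in this assay the expected step is a 1.2-fold higher number from compound 3 to compound 4 (0.08 log units; within the scatter), small, because the same change gave a 1.3-fold higher number from compound 1 to compound 2 (0.10 log units; within the scatter). The estimate for compound 4 is 170 nM, between 80 nM and 400 nM.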

Compound 4, half-maximal inhibitory concentration: 120 nM
Beside the measured number, compound 4's estimate is 1.4-fold (0.15 log units) above it, and the stated range covers the measured number.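

In this assay, 4-methylpiperazin-1-yl in place of 4-methylpiperidin-1-yl again leaves only a small step, a 1.2-fold lower number from compound 3 to compound 4 (0.07 log units; within the scatter), and the two cores agree on this change: the same change on two cores in this assay, a 1.3-fold higher number (0.10 log units; within the scatter) from compound 1 to compound 2 and a 1.2-fold lower number (0.07 log units; within the scatter) from compound 3 to compound 4, 1.5-fold (0.17 log units) apart, within the scatter of two such steps. The 3-fluorophenyl in place of 2-methylphenyl also carries over with the other chain amine, giving a 14-fold lower number from compound 2 to compound 4 (1.13 log units; beyond the scatter), and it agrees with the earlier step: the same change on two cores in this assay, a 9.2-fold lower number (0.96 log units; beyond the scatter) from compound 1 to compound 3 and a 14-fold lower number (1.13 log units; beyond the scatter) from compound 2 to compound 4, 1.5-fold (0.17 log units) apart, within the scatter of two such steps. Across compounds 1 to 4 the two changes therefore read as additive within the scatter, but this does not show that they stay so on other cores or in other assays, and it gives no reason for either step.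

As far as these compounds go, it remains open whether the small chain amine step holds with an unsubstituted phenyl on the aromatic nitrogen. Also open, from the compounds shown here alone, is how a morpholin-4-yl group or a longer chain would behave at the chain end.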